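Trimming the ether group of compound 2

The source may hold more compounds than are shown below. What is called first, only, known or untested is meant among the compounds shown, and "the series" means these compounds.

Compound 1 `C[C@@H](Oc1cc2oc(=O)n(CCC(=O)O)c2cc1Cl)c1cccnn1`: < 3 nm/s
Compound 2 `O=C(O)CCn1c(=O)oc2cc(OCC3CC3)c(Cl)cc21`: 19 nm/s

In a physicochemical assay for permeability, using PAMPA (on this read-out higher numbers stand for higher permeability and lower numbers for lower permeability), compound 1 gives < 3 nm/s, which is a limit. Among the compounds with values here, compound 2 gives 19 nm/s, the only true number so far. Compound 3 `COc1cc2oc(=O)n(CCC(=O)O)c2cc1Cl` differs from it by hydrogen in place of cyclopropyl on a saturated chain carbon bound to an oxygen on an aromatic ring, with hydrogen in place of cyclopropyl on a saturated chain carbon bound to an oxygen on an aromatic ring. Within the data shown here, the one measured step on that oxygen is an at least 6.3-fold higher number from compound 1 to compound 2 (0.80 log units; beyond the scatter), beyond the scatter, but it removed an aromatic ring, and no such ring leaves here. A modest fall is therefore expected, namely a 2.4-fold lower number from compound 2 to compound 3 (0.38 log units; beyond the scatter). For compound 3 the estimate in this assay is 8 nm/s, with an expected range from 3 nm/s to 20 nm/s.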

Compound 3, apparent permeability: < 3 nm/s
Compound 3: a limit, no number (the forecaster's own chance of this, stated with the estimate: 15%); middle value at least 2.6-fold (0.42 log units) away from the limit.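

In this assay, going from cyclopropylmethoxy to methoxy gives an at least 6.3-fold lower number from compound 2 to compound 3 (0.80 log units; beyond the scatter), so a fall on this oxygen does not require an aromatic ring to leave. The step from compound 1 to compound 3 cannot be read, as both values are limits. Compound 2 is thus the only compound with a true number, and the real size of the fall stays hidden: the limit of < 3 nm/s in this assay, at which 2 of the 3 values shown sit.

Going by these compounds, whether an ethoxy or propoxy chain would give a true number remains open. So does whether an open butoxy chain would match cyclopropylmethoxy.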